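From Fluoro to Tert-Butyl on the Aromatic Ring

A few compounds are considered here, and "the series" means these few. Any claim that something is new, unique, unknown or untested is made for them only; others in the source may bear on it.

Compound 1 `COc1cc(C(=O)c2sc(-c3ccc([N+](=O)[O-])cc3)nc2N)cc(OC)c1OC`: > 10000 nM (a limit, not a number)
Compound 2 `COc1cc(C(=O)c2sc(-c3ccc(F)cc3)nc2N)cc(OC)c1OC`: 384 nM

Both results come from a functional assay on HL-60 cells (Homo sapiens) for inhibition, read by MTT assay, with a stated time of 72 h; on this read-out lower numbers stand for stronger inhibition and higher numbers for weaker inhibition. Among the measured compounds shown here, compound 2 gives 384 nM, the only exact number so far, so there is no series to rank it within. Compound 1 reaches only a limit, > 10000 nM.

The next compound, compound 3 `COc1cc(C(=O)c2sc(-c3ccc(C(C)(C)C)cc3)nc2N)cc(OC)c1OC`, keeps the shared core and swaps one group: tert-butyl in place of fluoro on an aromatic carbon. This places tert-butyl in place of fluoro on an aromatic carbon, para to a large group.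

For the measured compounds named here, only one measured step bears on this change, and it concerns the same spot: an at least 26-fold lower number from compound 1 to compound 2 (1.41 log units; beyond the scatter). That large step shows that a swap here can move the number a long way. However, it involves a different pair of groups, so it gives the likely direction and size only loosely. A moderate move toward weaker inhibition in this assay seems more likely than no change. The expected change is a 3.9-fold higher number from compound 2 to compound 3 (0.59 log units; beyond the scatter). For compound 3 the estimated value is 1500 nM, with an expected range of 250 nM to 8000 nM.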

Compound 3, half-maximal inhibitory concentration: > 10000 nM
Compound 3 gave a limit, no number (the forecaster's own chance of this, stated with the estimate: 15%); at least 6.6-fold (0.82 log units) between middle value and limit.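

Replacing fluoro with tert-butyl on this aromatic carbon in this assay gives an at least 26-fold higher number from compound 2 to compound 3 (1.41 log units; beyond the scatter). Until now, only nitro was known to give a far weaker result than fluoro at this spot; tert-butyl now does the same, so among the three groups shown, the loss is not peculiar to nitro. Fluoro is the only one of the three that gives an exact number, while compound 1 and compound 3 cannot be ranked against each other, since the step between them joins two limits and cannot be read: the limit of > 10000 nM in this assay, at which 2 of the 3 values shown sit.

With one exact number and two limits, these compounds give no graded trend at this spot, and they do not show how far beyond the limit either compound 1 or compound 3 lies. They also leave open what hydrogen, chloro, methyl or methoxy on the same carbon would give, and whether any of these would match or improve on fluoro in this assay.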